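Moving a methoxy group on a phenoxy anilide

The source may hold more compounds than are shown below. What is called first, only, known or untested is meant among the compounds shown, and "the series" means these compounds.

Measured compounds:
- Compound 1, `COc1ccc(-c2cc(=O)c3c(OC)cc(OC)cc3n2S(=O)(=O)c2ccc(C)cc2)cc1`: > 44800 nM
- Compound 2, `COc1cc(OC)c2c(=O)cc(C(=O)Nc3cc(C(F)(F)F)ccc3Oc3ccccc3OC)[nH]c2c1`: 10700 nM

Of the compounds shown here, two have been tested in a functional assay on HepG2 cells (Homo sapiens) for antiproliferative activity, with a stated time of 72 h; on this read-out higher numbers stand for an effect only at larger amounts of compound and lower numbers for an effect already at smaller amounts. For compound 1 the result is a limit of the assay, not a number: compound 1 gives > 44800 nM. Among the compounds with values here, compound 2 is the only compound with a measured value, and in this assay compound 2 gives 10700 nM. That places compound 2 as the single point to work from, since (the limit of > 44800 nM in this assay, at which 1 of the 2 values shown sits).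

Compound 3, `COc1ccc(Oc2ccc(C(F)(F)F)cc2NC(=O)c2cc(=O)c3c(OC)cc(OC)cc3[nH]2)cc1`, has not yet been measured. It shares every atom with compound 2, joined differently: 4-methoxyphenyl in place of 2-methoxyphenyl on an oxygen on an aromatic ring. Put more broadly, a 2-methoxyphenoxy group becomes a 4-methoxyphenoxy group.

Within the data shown here, no pair of measured compounds differs in one place, so no step is known for comparison. The author expects the step of a 1.1-fold lower number from compound 2 to compound 3 (0.03 log units; within the scatter) to stay within the usual scatter, with no clear direction. On that basis compound 3 is estimated at 10000 nM in this assay, with a range from 3500 nM to 30000 nM.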

Compound 3, half-maximal effective concentration: 5300 nM
For compound 3 the middle estimate is 1.9-fold (0.28 log units) above the measured one; measured number inside the range.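

Read in this assay, the change from 2-methoxyphenoxy to 4-methoxyphenoxy gives a 2.0-fold lower number from compound 2 to compound 3 (0.31 log units; beyond the scatter) and is the first step available between compounds that differ in one place. It shows that this position on the phenoxy anilide responds to where the methoxy group stands on the ring, even though compound 2 and compound 3 contain the same atoms and the group that leaves and the group that enters have the same counts of heavy atoms, donors and acceptors. The step is modest, and nothing available here gives a reason for it.

The compounds shown leave open whether this lower number depends on the methoxy group itself, which a hydroxyl group, a chlorine atom or an unsubstituted phenyl ring on the same oxygen could help to settle. They also leave open whether the same change would give a similar step if an amine stood in place of the trifluoromethyl group elsewhere in the molecule.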